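From isopropyl to hydroxymethyl on the shared core

The source may hold more compounds than are shown below. What is called first, only, known or untested is meant among the compounds shown, and "the series" means these compounds.

Measured in an ADME assay on L1210 cells (Mus musculus) for cytotoxicity, with a stated time of 48 h; a lower number here means a stronger inhibitor, a higher number a weaker inhibitor:
compound 1 `CC1=CCC[C@](C)(CC/C(C)=C/CC2=C(O)C(=O)C=C(N[C@@H](C(=O)O)[C@@H](C)O)C2=O)[C@@H]1C`: > 10 ug/mL (a limit of the assay, not a number)
compound 2 `CC1=CCC[C@](C)(CC/C(C)=C/CC2=C(O)C(=O)C=C(N[C@@H](C(=O)O)C(C)C)C2=O)[C@@H]1C`: 3 ug/mL

Going by the values given here, compound 2 holds the only actual number so far, 3 ug/mL. Compound 1 gives only a limit, > 10 ug/mL.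

Compound 3 `CC1=CCC[C@](C)(CC/C(C)=C/CC2=C(O)C(=O)C=C(N[C@H](CO)C(=O)O)C2=O)[C@@H]1C` differs from compound 2 as follows: hydroxymethyl in place of isopropyl on a saturated chain carbon bound to an amine nitrogen and a carbonyl carbon. It carries hydroxymethyl in place of isopropyl on a saturated chain carbon bound to an amine nitrogen and a carbonyl carbon.

Among the compounds with values here, one measured step bears on this change: an at least 3.3-fold lower number from compound 1 to compound 2 (0.52 log units; beyond the scatter). There, isopropyl replaced 1-hydroxyethyl at that same place, and the number fell by more than the scatter. Within the data shown here, the new change runs the other way, from isopropyl to a hydroxyl-bearing group, although hydroxymethyl is not 1-hydroxyethyl and this single step is the only guide. A step of similar size towards a higher number is therefore expected in this assay, and a result reported only as a limit would be no surprise.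

The expected step is a 3.3-fold higher number from compound 2 to compound 3 (0.52 log units; beyond the scatter). Compound 3 is estimated at 10 ug/mL, with an expected range of 4 ug/mL to 30 ug/mL.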

Compound 3, half-maximal inhibitory concentration: > 10 ug/mL
Compound 3 was reported as a limit; the forecaster's own chance of this, stated with the estimate: 50%; the middle value lies on the limit itself.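

In this assay, the place on the saturated chain carbon bound to an amine nitrogen and a carbonyl carbon now responds to a second hydroxyl-bearing group, with an at least 3.3-fold higher number from compound 2 to compound 3 (0.52 log units; beyond the scatter). Of the three groups shown here, only the isopropyl of compound 2 gives an actual number, whereas 1-hydroxyethyl and hydroxymethyl, the two groups that carry a hydroxyl, both end at a limit of the assay: the limit of > 10 ug/mL in this assay, at which 2 of the 3 values shown sit. The step that separates those two hydroxyl-bearing groups, hydrogen in place of methyl, cannot be read, as both of its ends are limits and not numbers.

Where compound 1 and compound 3 truly lie beyond their limits stays open, and so does any order between them. Also open, from the compounds shown here alone, is how the number would respond at this place to a group without a hydroxyl other than isopropyl, such as a plain methyl, a benzyl or a longer chain, or to an amine or a second carboxylic acid.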